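The compounds below may be only part of what the source reports. "The series", "measured", "known", "first", "only" and "open" are said of these compounds alone.

Measured in an ADME assay on MT4 cells (Homo sapiens) for cytotoxicity, read by MTT assay, with a stated time of 4 days; on this read-out lower numbers stand for higher toxicity in this test and higher numbers for lower toxicity in this test:
compound 1 `Cc1cc(-c2ccc(F)cc2)cc(C)c1Nc1ccnc(Nc2ccc(C#N)cc2)n1` gives 4170 nM
compound 2 `Cc1cc(-c2ccccc2Cl)cc(C)c1Nc1ccnc(Nc2ccc(C#N)cc2)n1` gives 3990 nM

Compound 2 holds the lowest of the two numbers in this assay; its nearest neighbour is compound 1, and the step from compound 1 to compound 2 was a 1.0-fold lower number from compound 1 to compound 2 (0.02 log units; within the scatter), so the two stand within the scatter of each other.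

Compound 3 `COc1cccc(-c2cc(C)c(Nc3ccnc(Nc4ccc(C#N)cc4)n3)c(C)c2)c1` is not yet measured. It differs from compound 2 by 3-methoxyphenyl in place of 2-chlorophenyl on an aromatic carbon.

Among the compounds with values here, only one measured step bears on this position: the exchange of one aryl group for another in the step from compound 1 to compound 2, which was a 1.0-fold lower number from compound 1 to compound 2 (0.02 log units; within the scatter). That single step is the whole basis, and it shows no movement beyond the scatter when the aryl group at this place is varied. For compound 3 the expected step is therefore a 1.0-fold higher number from compound 2 to compound 3 (0.00 log units; within the scatter), no change beyond the scatter in either direction. Compound 3 is estimated at 4000 nM, with a range from 1500 nM to 10000 nM.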

Compound 3, half-maximal cytotoxic concentration: 2990 nM
The estimate for compound 3 lay 1.3-fold (0.13 log units) above the measured number; the measured number falls inside the stated range.
By their numbers in this assay, from the lowest: compounds 3, 2 and 1 (each within the scatter of the next).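

In this assay, a third aryl group at this place, para to a large group, gives a 1.3-fold lower number from compound 2 to compound 3 (0.13 log units; within the scatter), and the comparison with the 4-fluorophenyl compound gives a 1.4-fold lower number from compound 1 to compound 3 (0.14 log units; within the scatter). The read-out therefore does not separate 2-chlorophenyl, 4-fluorophenyl and 3-methoxyphenyl at this position. This holds even though 3-methoxyphenyl counts a hydrogen-bond acceptor where 2-chlorophenyl counts none, so the earlier flat step now extends to an oxygen-bearing aryl group.

On these data alone, it remains open whether the numbers stay together with an aryl group carrying an amine or a carboxylic acid, or with a longer alkyl chain in place of the aryl ring. No available data bear on why the three compounds stand so close.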